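The compounds below may be only part of what the source reports. "The series", "measured", "known", "first", "only" and "open" are said of these compounds alone.

In a functional assay on KBVIN cells (Homo sapiens) for antiproliferative activity, read by sulforhodamine B assay, with a stated time of 3 days (a lower number here means that less compound is needed, a higher number that more compound is needed for the effect), compound 1 (`CCC1=C(O)c2c(oc(-c3ccc(C)c(C)c3)cc2=O)C(CC)(CC)C1=O`) gives 0.71 uM, compound 2 (`CCC1=C(O)c2c(oc(-c3cc(C)c(C)cc3C)cc2=O)C(CC)(CC)C1=O`) gives 4.37 uM and compound 3 (`CCC1=C(O)c2c(oc(-c3ccc(OC)c(Cl)c3)cc2=O)C(CC)(CC)C1=O`) gives 1.37 uM. The position of compound 3 is set by two gaps: a 1.9-fold higher number from compound 1 to compound 3 (0.29 log units; within the scatter) and a 3.2-fold lower number from compound 2 to compound 3 (0.50 log units; beyond the scatter). Only the second of these can be told apart from the scatter.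

Compound 4 (`CCC1=C(O)c2c(oc(-c3ccc(O)c(O)c3)cc2=O)C(CC)(CC)C1=O`) keeps the shared core and carries 3,4-dihydroxyphenyl in place of 3-chloro-4-methoxyphenyl, on an aromatic carbon next to the ring oxygen: 3,4-dihydroxyphenyl in place of 3-chloro-4-methoxyphenyl on an aromatic carbon. Among the compounds with values here, no measured compound carries this group, so the measured steps bear on the change only indirectly. Within the data shown here, they show how far a change to this aryl group has moved the number so far. Besides the two gaps above, methyl in place of hydrogen on an aromatic carbon gave a 6.2-fold higher number from compound 1 to compound 2 (0.79 log units; beyond the scatter), the largest step seen. These steps set a modest size but give no firm direction, so a rise in this assay is only a cautious expectation. The expected step is a 2.6-fold higher number from compound 3 to compound 4 (0.41 log units; beyond the scatter). Compound 4 is estimated at 3.5 uM, with an expected range from 1 uM to 12 uM.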

Compound 4, concentration for half-maximal effect: 5.41 uM
For compound 4 the middle estimate is 1.5-fold (0.19 log units) below the measured one, within the range that was stated.
By their numbers in this assay, from the lowest: compounds 1 and 3 (each within the scatter of the next); then compounds 2 and 4 (each within the scatter of the next).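

In this assay, 3,4-dihydroxyphenyl is the only aryl group shown at this position, on an aromatic carbon next to the ring oxygen, that carries hydrogen-bond donors, and replacing 3-chloro-4-methoxyphenyl with it gives a 3.9-fold higher number from compound 3 to compound 4 (0.60 log units; beyond the scatter) and so moves the number clearly beyond the gap left by the earlier change to the chloro and methoxy pair. Set against 3,4-dimethylphenyl, the same group gives a 7.6-fold higher number from compound 1 to compound 4 (0.88 log units; beyond the scatter) as the largest step yet seen at this position, while against 2,4,5-trimethylphenyl it gives a 1.2-fold higher number from compound 2 to compound 4 (0.09 log units; within the scatter) and so shows that two aryl groups with quite different substituents can share the upper end of the range of numbers. Nothing available here accounts for the rise in the number with the two hydroxy groups.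

The compounds shown leave open whether one hydroxy group alone, as in 3-hydroxyphenyl or 4-hydroxyphenyl, would give the same step as the pair, or whether 3,4-dimethoxyphenyl would behave like 3,4-dihydroxyphenyl or like 3-chloro-4-methoxyphenyl. They also say nothing about an aryl group bearing an amine or a carboxylic acid at this position.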